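Swapping trifluoromethyl for methoxy on an already weak compound

A few compounds are considered here, and "the series" means these few. Any claim that something is new, unique, unknown or untested is made for them only; others in the source may bear on it.

A set of three compounds sharing one core were tested in a functional assay on A549 cells (Homo sapiens) for antiproliferative activity, read by MTT assay, with a stated time of 24 h; a lower number here means a stronger inhibitor, a higher number a weaker inhibitor. Compound 1, `FC(F)(F)c1ccc(C2CC(c3ccccc3)=NN2c2ccc(-c3ccccc3)nn2)cc1`, gives 9160 nM in this assay. Compound 2, `COc1ccc(C2CC(c3ccccc3)=NN2c2ccc(-c3ccccc3)nn2)cc1`, differs from compound 1 in one place: methoxy in place of trifluoromethyl on an aromatic carbon. In this assay compound 2 gives 91700 nM, which makes the step of a 10-fold higher number from compound 1 to compound 2 (1.00 log units; beyond the scatter). Compound 3, `COc1ccc(C2=NN(c3ccc(-c4ccccc4)nn3)C(c3ccc(C(F)(F)F)cc3)C2)cc1`, differs from compound 1 in another way: methoxy in place of hydrogen on an aromatic carbon. In this assay compound 3 reaches only a limit of the assay, > 100000 nM. Counted from compound 1, this is an at least 10-fold higher number from compound 1 to compound 3 (1.03 log units; beyond the scatter). The point where compound 3 sits is the limit of > 100000 nM in this assay, at which 1 of the 3 values shown sits.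

Compound 4, `COc1ccc(C2=NN(c3ccc(-c4ccccc4)nn3)C(c3ccc(OC)cc3)C2)cc1`, has not yet been measured. It is related to compound 3 by methoxy in place of trifluoromethyl on an aromatic carbon. The place of this change is described in the same words as for the pair compound 1 to compound 2, so it is the same change, made on a core that differs from the core of compound 1 by the methoxy in place of hydrogen described above. Since the earlier step read a 10-fold higher number from compound 1 to compound 2 (1.00 log units; beyond the scatter), the same direction is expected here, starting from a compound that is already at the limit. The expected step is a step that the limit leaves unreadable from compound 3 to compound 4. For compound 4 the expected value is 400000 nM, plausibly between 100000 nM and 2000000 nM, and it will most likely again be reported only as a limit.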

Compound 4, half-maximal inhibitory concentration: > 100000 nM
Compound 4 gave a limit, no number; the forecaster's own chance of this, stated with the estimate: 90%; the middle value does not contradict the limit.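

In this assay, compound 3 and compound 4 both stop at a limit of the assay, so the step between them cannot be read and the swap of trifluoromethyl for methoxy cannot be sized on this core: the limit of > 100000 nM in this assay, at which 2 of the 4 values shown sit. Going by these compounds alone, the only step that can be read here belongs to the other change, methoxy in place of hydrogen on an aromatic carbon, and it is only a floor, an at least 1.0-fold higher number from compound 2 to compound 4 (0.03 log units; that floor lies within the scatter), so it cannot show whether that change acts alike on both cores: the same change on two cores in this assay, an at least 10-fold higher number (1.03 log units; beyond the scatter) from compound 1 to compound 3 and an at least 1.0-fold higher number (0.03 log units; that floor lies within the scatter) from compound 2 to compound 4; the limit leaves it open whether they differ. Within the data shown here, the result does not contradict the earlier step on the core of compound 1, a 10-fold higher number from compound 1 to compound 2 (1.00 log units; beyond the scatter), but it does not show that this step carries over to the second core either, only that neither compound on that core gives a number.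

The compounds shown leave open how large either change really is on the second core, which would take a compound on that core with a value inside the range of the assay. They also leave open whether an amine or a carboxylic acid on that same aromatic carbon would give such a value.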